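Chloro on the Styryl Ring of an Acrylophenone Dimer

The compounds below may be only part of what the source reports. "The series", "measured", "known", "first", "only" and "open" are said of these compounds alone.

Of the compounds shown here, three have been tested in a functional assay on SW1573 cells (Homo sapiens) for inhibition, read by sulforhodamine B assay, with a stated time of 48 h; on this read-out higher numbers stand for weaker inhibition of growth and lower numbers for stronger inhibition of growth. Compound 1 `CC(=O)OC/C(=C/c1ccccc1Br)C(=O)c1ccccc1` gives 21000 nM, and compound 2 `O=C(OC/C(=C/c1ccc(Cl)cc1Cl)C(=O)c1ccccc1)c1ccccc1` gives 29000 nM. Compound 3 `C=C(C/C(=C\c1ccccc1)C(=O)c1ccccc1)C(=O)c1ccccc1` gives 3000 nM, the lowest of the three numbers and the strongest growth inhibitor here, since its gaps to compound 1 and to compound 2 both lie beyond the scatter. Compound 4 `C=C(C/C(=C\c1ccc(Cl)cc1)C(=O)c1ccccc1)C(=O)c1ccccc1` is unmeasured; it differs from compound 3 by chloro in place of hydrogen on an aromatic carbon. Among the measured compounds shown here, no measured pair shows this single change, so the step is a judgement. The change from compound 3 to compound 4 is expected to be small, a 1.2-fold lower number from compound 3 to compound 4 (0.08 log units; within the scatter), probably within the scatter. Compound 4 is therefore expected to give about 2500 nM, in a range from 800 nM to 8000 nM.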

Compound 4, concentration for 50% growth inhibition: 6100 nM
For compound 4 the middle estimate is 2.4-fold (0.39 log units) below the measured one; the measured number falls inside the stated range.
By their numbers in this assay, from the lowest: compound 3; then compound 4; then compounds 1 and 2 (each within the scatter of the next).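

Among the compounds shown here, with phenyl giving way to 4-chlorophenyl, this is the first single change that can be read in this assay (a 2.0-fold higher number from compound 3 to compound 4 (0.31 log units; beyond the scatter)). Adding chloro at this place, para to a large group, modestly weakens growth inhibition rather than strengthening it. The step lies beyond the scatter, but nothing at hand accounts for the loss.

From the compounds shown here alone, it remains open whether fluoro or methoxy at the same place would also weaken growth inhibition. Going by these compounds, it is equally open whether an amine there would restore it.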